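A Second Fluorine on the Ring of Compound 3

A few compounds are considered here, and "the series" means these few. Any claim that something is new, unique, unknown or untested is made for them only; others in the source may bear on it.

Compound 1 `Cc1cc(=O)n(-c2ccccc2C(F)(F)F)nc1C(=O)Nc1ccc(Oc2ncnc3ccsc23)cc1`, compound 2 `Cc1cc(=O)n(-c2ccccc2C(F)(F)F)nc1C(=O)Nc1ccc(Oc2ncnc3ccsc23)c(F)c1` and compound 3 `Cc1cc(=O)n(-c2ccc(F)cc2)nc1C(=O)Nc1ccc(Oc2ncnc3ccsc23)c(F)c1` have been measured in a functional assay on MCF7 cells (Homo sapiens) for cytotoxicity, read by MTT assay, with a stated time of 72 h; a lower number here means a stronger inhibitor, a higher number a weaker inhibitor; compound 4 `Cc1cc(=O)n(-c2ccc(F)c(F)c2)nc1C(=O)Nc1ccc(Oc2ncnc3ccsc23)c(F)c1` has not. In this assay compound 1 gives 5550 nM, compound 2 gives 6020 nM and compound 3 gives 740 nM. The change from compound 1 to compound 2, (fluoro in place of hydrogen on an aromatic carbon), produced a 1.1-fold higher number from compound 1 to compound 2 (0.04 log units; within the scatter). The change from compound 2 to compound 3 produced an 8.1-fold lower number from compound 2 to compound 3 (0.91 log units; beyond the scatter), and compound 3 therefore stands as the lowest of the three numbers. The difference between the cores of compound 1 and compound 3 is not broken down here.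

Compound 4 differs from compound 3 by fluoro in place of hydrogen on an aromatic carbon. Going by the values given here, this is the same kind of change as the one from compound 1 to compound 2, but the surroundings differ: in compound 4 the entering fluoro sits ortho to a fluoro group, whereas in compound 2 it sat ortho to a large group. Because the same kind of change earlier gave a 1.1-fold higher number from compound 1 to compound 2 (0.04 log units; within the scatter), the step from compound 3 to compound 4 is expected to be a 1.1-fold higher number from compound 3 to compound 4 (0.03 log units; within the scatter). On that basis compound 4 is expected to give about 800 nM in this assay, most likely between 400 nM and 1600 nM.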

Compound 4, half-maximal inhibitory concentration: 6900 nM
For compound 4 the middle estimate is 8.6-fold (0.94 log units) below the measured one; measured number outside the range, above it.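

In this assay, adding a fluoro to an aromatic carbon did not carry over from one core to the other, and the two results differ: the same change on two cores in this assay, a 1.1-fold higher number (0.04 log units; within the scatter) from compound 1 to compound 2 and a 9.3-fold higher number (0.97 log units; beyond the scatter) from compound 3 to compound 4, 8.6-fold (0.93 log units) apart, beyond the scatter of two such steps.

On compound 3 the added fluoro mattered greatly, giving a 9.3-fold higher number from compound 3 to compound 4 (0.97 log units; beyond the scatter) as the step, and the 3,4-difluorophenyl group leaves compound 4 close to compound 2, with a 1.1-fold higher number from compound 2 to compound 4 (0.06 log units; within the scatter) as the step between them. These two pairs do not show why the outcome changed, since the fluoro enters a different place in each pair and the surroundings also differ, so they give no general rule for other cores in this series.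

The compounds shown leave open whether the loss of activity in compound 4 belongs to fluoro in particular or to any added group on that aromatic carbon. A chloro or a methoxy group on the same carbon of compound 3 would help to separate these two readings.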